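A few compounds are considered here, and "the series" means these few. Any claim that something is new, unique, unknown or untested is made for them only; others in the source may bear on it.

In a functional assay on Bel-7402 cells (Homo sapiens) for inhibition, read by MTT assay, with a stated time of 24 h, tested at 1 ug/mL (on this read-out lower numbers stand for less inhibition of growth and higher numbers for more inhibition of growth at the one concentration tested), compound 1 (`O=C(CCCCC(S)CCS)Nc1cccc(Cl)c1`) gives 1.14% at the single concentration tested. Compound 2 (`O=C(CCCCC(S)CCS)Nc1ccc(Cl)cc1`) gives 0.27% in the same test, and compound 3 (`O=C(CCCCC(S)CCS)Nc1ccc([N+](=O)[O-])c(C(F)(F)F)c1`) gives 0.68% there. These three numbers lie within the scatter of one another, so compound 1 cannot be separated from the other two. Compound 4 (`Cc1cccc(NC(=O)CCCCC(S)CCS)c1`) has methyl in place of chloro on an aromatic carbon and is otherwise the same as compound 1. Among the compounds with values here, no measured pair differs in one place alone, so the expectation rests on compound 1 with its 1.14% as the starting point. The expected step of a number 0.4 percentage points higher from compound 1 to compound 4 (within the scatter) is none beyond the scatter, in no clear direction. For compound 4 the estimated value is 1.5% within a range from 0% to 8% in this test.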

Compound 4, percent growth inhibition at one concentration: 11.1%
Beside the measured number, compound 4's estimate is 9.6 percentage points below it, and the stated range ends below it.
By their numbers in this assay, from the lowest: compounds 2, 3, 1 and 4 (each within the scatter of the next, the first and the last beyond it).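

Within the data shown here, compound 4 and compound 1 form the first pair here that differs in one place, so this change can now be read directly. In this assay, methyl in place of chloro on an aromatic carbon, meta to a large group, gives a number 10 percentage points higher from compound 1 to compound 4 (within the scatter), so this pair does not establish an effect of the swap. No supporting measurement is available to explain this step. On these data alone, whether an amine or a carboxylic acid at this place would give a step beyond the usual scatter remains open.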